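Shortening the alkyl chain in a diaryl urea series

This account rests on a few compounds, and the source may have more. Where it says the series, first, only, none or still open, it means among the compounds named here.

Three ureas share a core and differ only in the chain on the phenyl ring: compound 1 `CCCCCCCCCCCCCCc1ccc(NC(=O)Nc2c(C(C)C)cccc2C(C)C)cc1`, compound 2 `CCCc1ccc(NC(=O)Nc2c(C(C)C)cccc2C(C)C)cc1` and compound 3 `CCCCCCCCCCCCc1ccc(NC(=O)Nc2c(C(C)C)cccc2C(C)C)cc1`. In an assay on isolated protein for inhibition of acyl-CoA:cholesterol acyltransferase (Oryctolagus cuniculus) (on this read-out lower numbers stand for stronger inhibition and higher numbers for weaker inhibition), compound 1 gives 500 nM, compound 2 gives 38 nM and compound 3 gives 15 nM. Thus a 13-fold lower number from compound 1 to compound 2 (1.12 log units; beyond the scatter), a 33-fold lower number from compound 1 to compound 3 (1.52 log units; beyond the scatter) and a 2.5-fold lower number from compound 2 to compound 3 (0.40 log units; beyond the scatter). Compound 4 `Cc1ccc(NC(=O)Nc2c(C(C)C)cccc2C(C)C)cc1` is not yet measured. It differs from compound 3 by hydrogen in place of undecyl on a saturated chain carbon bound to an aromatic carbon; compound 2 differs from compound 1 by hydrogen in place of undecyl on a saturated chain carbon, three bonds along the chain from an aromatic carbon, the same kind of change but at a different place, three bonds along the chain rather than bound to an aromatic carbon. The two cores differ by hydrogen in place of ethyl on a saturated chain carbon, ten or more bonds along the chain from an aromatic carbon. Since compound 3 already shows a lower number than compound 2, which gives 38 nM, compound 4 is expected to give a higher number still, a 10-fold higher number from compound 3 to compound 4 (1.00 log units; beyond the scatter), unlike the earlier step. Compound 4 is estimated at 150 nM, between 40 nM and 600 nM.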

Compound 4, half-maximal inhibitory concentration: 250 nM
Compound 4: middle estimate off by 1.7-fold (0.22 log units), on the low side; the range from low to high includes it.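

In this assay, replacing undecyl with hydrogen does not carry over from one core to the other, as the step runs in opposite directions on the two cores: the same change on two cores in this assay, a 13-fold lower number (1.12 log units; beyond the scatter) from compound 1 to compound 2 and a 17-fold higher number (1.22 log units; beyond the scatter) from compound 3 to compound 4, 220-fold (2.34 log units) apart, beyond the scatter of two such steps

Replacing ethyl with hydrogen, which gives a 6.6-fold higher number from compound 2 to compound 4 (0.82 log units; beyond the scatter), also fails to carry over, and the step from compound 3 to compound 4 is a 17-fold higher number from compound 3 to compound 4 (1.22 log units; beyond the scatter): the same change on two cores in this assay, a 33-fold lower number (1.52 log units; beyond the scatter) from compound 1 to compound 3 and a 6.6-fold higher number (0.82 log units; beyond the scatter) from compound 2 to compound 4, 220-fold (2.34 log units) apart, beyond the scatter of two such steps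

Thus the outcome of each change depends on the core carrying it, but each comparison rests on only two steps, and these do not show why the steps differ.

The compounds shown leave open how intermediate chains, such as hexyl or octyl, would compare. They also leave open what a carboxylic acid or an amine at the chain end would do.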